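Chloro for hydrogen on two cores: tolerated concentration notes

This account rests on a few compounds, and the source may have more. Where it says the series, first, only, none or still open, it means among the compounds named here.

Compound 1 `C1=C(/C=C/c2ccccn2)COc2ccccc21` and compound 2 `Clc1ccc2c(c1)C=C(/C=C/c1ccccn1)CO2` share a core and differ by chloro in place of hydrogen on an aromatic carbon. In an ADME assay on HeLa cells (Homo sapiens) for cytotoxicity, read by XTT assay, with a stated time of 3 days (a higher number here means that more compound is tolerated, a lower number that less compound is tolerated), compound 1 gives > 50000 nM, which is a limit of the assay and not a number. Compound 2 gives > 50000 nM, likewise a limit. The step from the one to the other is a step that the two limits leave unreadable from compound 1 to compound 2. Compound 3 `O=c1c(/C=C\c2cccnc2)coc2ccccc12` stands on another core; the difference between the two cores is not broken down here. In this assay compound 3 gives > 200000 nM, again a limit. For the measured compounds named here, two of the three values sit at the limit of > 50000 nM in this assay, at which 2 of the 3 values shown sit, one at the limit of > 200000 nM in this assay, at which 1 of the 3 values shown sits, so no measured step has a readable size.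

Compound 4 `O=c1c(/C=C\c2cccnc2)coc2ccc(Cl)cc12`, not yet measured, carries the same change as seen between compound 1 and compound 2, namely (chloro in place of hydrogen on an aromatic carbon), at a place described in the same words. From compound 3 to compound 4 the step is expected to be a number no higher from compound 3 to compound 4 (the limit leaves the size open), resting on the unreadable a step that the two limits leave unreadable from compound 1 to compound 2 and on compound 3 sitting at a limit, > 200000 nM. Compound 4 is therefore expected to come out near 200000 nM in this assay, most likely again as a limit rather than a number.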

Compound 4, half-maximal cytotoxic concentration: 50000 nM
The estimate for compound 4 lay 4.0-fold (0.60 log units) above the measured number; the whole stated range lies above it.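

In this assay, chloro in place of hydrogen on an aromatic carbon gives an at least 4.0-fold lower number from compound 3 to compound 4 (0.60 log units; beyond the scatter), so on this one core the change has a readable result, and that result lies beyond the scatter. Compound 3 sits at a limit of the assay and not at a number, so the step has a lower bound on its size but no exact size: the limit of > 200000 nM in this assay, at which 1 of the 4 values shown sits. The step from compound 1 to compound 2 cannot be read, as both values are limits, so the series does not show whether the same change gives a similar result on both cores.

The compounds shown leave open whether the lower number belongs to chloro in particular or would also appear with another group at this place, such as methoxy, an amine or a carboxylic acid. Also open, going by these compounds, is whether chloro gives the same result at other places on this aromatic ring.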